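This account rests on a few compounds, and the source may have more. Where it says the series, first, only, none or still open, it means among the compounds named here.

Of the compounds shown here, three built on one shared core have been measured in an assay on isolated protein for inhibition of Leucine-rich repeat serine/threonine-protein kinase 2 (Homo sapiens), in the presence of a further agent that is not named here; on this read-out lower numbers stand for stronger inhibition and higher numbers for weaker inhibition. Compound 1 `COc1ccc(OC)c(Sc2ccc3nnc(-c4ccccn4)n3n2)c1` gives 496 nM. Compound 2 `COc1ccc(OC)c(Sc2ccc3nnc(C4CCN(C)C4)n3n2)c1` gives 12600 nM. Compound 3 `COc1ccc(OC)c(Sc2ccc3nnc(-c4ccn(C)n4)n3n2)c1` gives 224 nM, the lowest of the three numbers; its nearest neighbour is compound 1 and its furthest is compound 2. The steps among them are uneven: a 25-fold higher number from compound 1 to compound 2 (1.40 log units; beyond the scatter) and a 56-fold lower number from compound 2 to compound 3 (1.75 log units; beyond the scatter), whereas a 2.2-fold lower number from compound 1 to compound 3 (0.35 log units; beyond the scatter).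

Compound 4 `COc1ccc(OC)c(Sc2ccc3nnc(-c4cn(C)nc4C)n3n2)c1` has not yet been measured. It differs from compound 3 in one place: 1,3-dimethyl-1H-pyrazol-4-yl in place of 1-methyl-1H-pyrazol-3-yl on an aromatic carbon. The large steps involving compound 2 show that exchanging an aromatic ring for a saturated one on that aromatic carbon moves the number a great deal, while the modest step from compound 1 to compound 3 shows that exchanging one aromatic ring for another moves it only a little. The change to compound 4 keeps a five-membered aromatic ring with 2 hetero atoms on the same aromatic carbon, so in this assay only a small step is expected, possibly none beyond the scatter, leaning toward a somewhat higher number. Compound 4 is therefore estimated at 400 nM, within a range of 150 nM to 1200 nM, which would mean an expected step of a 1.8-fold higher number from compound 3 to compound 4 (0.25 log units; within the scatter).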

Compound 4, half-maximal inhibitory concentration: 323 nM
Estimate against measurement, compound 4: 1.2-fold (0.09 log units) above, within the range that was stated.
By their numbers in this assay, from the lowest: compounds 3, 4 and 1 (each within the scatter of the next, the first and the last beyond it); then compound 2.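

In this assay, replacing 1-methyl-1H-pyrazol-3-yl with 1,3-dimethyl-1H-pyrazol-4-yl on the aromatic carbon between two ring nitrogen atoms gives a 1.4-fold higher number from compound 3 to compound 4 (0.16 log units; within the scatter), so this position accommodates both a different point of attachment on the pyrazole and an added methyl with no shift beyond the scatter. The earlier compounds shown here separated pyridin-2-yl from 1-methyl-1H-pyrazol-3-yl, but the new pyrazole also shows a 1.5-fold lower number from compound 1 to compound 4 (0.19 log units; within the scatter), which links the three aromatic groups in a close set, while a 39-fold lower number from compound 2 to compound 4 (1.59 log units; beyond the scatter) confirms the distance of the saturated 1-methylpyrrolidin-3-yl in compound 2 from that set. The data shown offer no measured explanation for any of these steps.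

Since the point of attachment and the added methyl change together in compound 4, the contribution of each remains unresolved. On these data alone, it also remains open whether the weaker result for compound 2 extends to other non-aromatic groups at this position, such as morpholine or a primary amine, or how an unsubstituted phenyl ring or a carboxylic acid would compare with the aromatic groups.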